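Ring Swap on an Aromatic Nitrogen in Two Related Cores

The source may report more compounds than this note shows. Statements on the series, on what has been measured and on what is new or still open speak of the compounds shown alone.

Compound 1 `CN1CCN(c2ccc(Nc3ncc4nc(Sc5ccccc5)n(C5CCOCC5)c4n3)cc2)CC1` and compound 2 `CC(C)n1c(Sc2ccccc2)nc2cnc(Nc3ccc(N4CCN(C)CC4)cc3)nc21` share one core. In a functional assay on HCC827 cells (Homo sapiens) for antiproliferative activity, read by MTT assay, with a stated time of 72 h (on this read-out higher numbers stand for weaker inhibition and lower numbers for stronger inhibition), compound 1 gives 42.6 nM, whereas compound 2 gives 290 nM. The two differ in a single change, (oxan-4-yl in place of isopropyl on an aromatic nitrogen), and that change brought a 6.8-fold lower number from compound 2 to compound 1 (0.83 log units; beyond the scatter). Compound 3 `CC(C)n1c([S+]([O-])c2ccccc2)nc2cnc(Nc3ccc(N4CCN(C)CC4)cc3)nc21` carries a different core, and the difference from compound 2 is a group of 8 heavy atoms (6 carbon, 1 oxygen, 1 sulfur; one six-membered aromatic ring of carbon only) in place of a group of 7 heavy atoms (6 carbon, 1 sulfur; one six-membered aromatic ring of carbon only), on an aromatic carbon. In this assay compound 3 gives 215 nM, so the core change amounts to a 1.3-fold lower number from compound 2 to compound 3 (0.13 log units; within the scatter).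

Compound 4 `CN1CCN(c2ccc(Nc3ncc4nc([S+]([O-])c5ccccc5)n(C5CCOCC5)c4n3)cc2)CC1` has not yet been measured. It is reached from compound 3 by oxan-4-yl in place of isopropyl on an aromatic nitrogen. For the measured compounds named here, this is the same kind of change as the one that leads from compound 2 to compound 1, though the surroundings are not identical: in compound 2 the aromatic nitrogen sits next to the ring atom that bears a phenylsulfanyl group (7 heavy atoms), while in compound 3 it sits next to the ring atom that bears a group of 8 heavy atoms. Compound 4 is therefore expected to show a step of a 5.7-fold lower number from compound 3 to compound 4 (0.75 log units; beyond the scatter) because the earlier move gave a 6.8-fold lower number from compound 2 to compound 1 (0.83 log units; beyond the scatter). Compound 4 is estimated at 38 nM in this assay, with a likely range from 15 nM to 110 nM.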

Compound 4, half-maximal inhibitory concentration: 411 nM
The estimate for compound 4 lay 11-fold (1.03 log units) below the measured number, and the stated range ends below it.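

Oxan-4-yl in place of isopropyl on an aromatic nitrogen gives a 1.9-fold higher number from compound 3 to compound 4 (0.28 log units; within the scatter) in this assay, so the step seen on the core of compound 2 does not reappear on the core of compound 3: the same change on two cores in this assay, a 6.8-fold lower number (0.83 log units; beyond the scatter) from compound 2 to compound 1 and a 1.9-fold higher number (0.28 log units; within the scatter) from compound 3 to compound 4, 13-fold (1.11 log units) apart, beyond the scatter of two such steps Read the other way, the group of 8 heavy atoms in place of phenylsulfanyl gives a 9.6-fold higher number from compound 1 to compound 4 (0.98 log units; beyond the scatter) with oxan-4-yl on the aromatic nitrogen, which does not match the same change made with isopropyl there: the same change on two cores in this assay, a 1.3-fold lower number (0.13 log units; within the scatter) from compound 2 to compound 3 and a 9.6-fold higher number (0.98 log units; beyond the scatter) from compound 1 to compound 4, 13-fold (1.11 log units) apart, beyond the scatter of two such steps These four compounds show that the two changes do not act independently in this series, so the size of the ring swap cannot be carried from one core to the other, but they do not show why, and they rest on a single set of paired steps.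

From the compounds shown here alone, it remains open whether a cyclohexyl or a piperidin-4-yl group on the aromatic nitrogen would depend on the core in the same way. Going by these compounds, it is equally open whether a phenylsulfonyl group on the aromatic carbon would follow compound 3 or compound 2.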